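Removing the para methyl from compound 3

The compounds below may be only part of what the source reports. "The series", "measured", "known", "first", "only" and "open" are said of these compounds alone.

Compound 1 `C=C1CCC[C@]2(C)CCC(c3cn(-c4ccc(OC)cc4)nn3)=CC[C@@]12C`: 34700 nM
Compound 2 `C=C1CCC[C@]2(C)CCC(c3cn(-c4cccc([N+](=O)[O-])c4)nn3)=CC[C@@]12C`: 24700 nM
Compound 3 `C=C1CCC[C@]2(C)CCC(c3cn(CC(=O)Nc4ccc(C)cc4)nn3)=CC[C@@]12C`: 270000 nM

All three compounds share a core and were measured in a functional assay on A549 cells (Homo sapiens) for cytotoxicity, read by MTT assay, with a stated time of 48 h; a higher number here means a weaker inhibitor, a lower number a stronger inhibitor. Compound 1 and compound 2 carry a substituted phenyl group on an aromatic nitrogen, while compound 3 carries a (4-methylphenyl)carbamoyl group instead. Compound 3, at 270000 nM, has the highest number of the three, clearly above compound 1 at 34700 nM and compound 2 at 24700 nM.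

The next compound, compound 4 `C=C1CCC[C@]2(C)CCC(c3cn(CC(=O)Nc4ccccc4)nn3)=CC[C@@]12C`, differs from compound 3 in one place: hydrogen in place of methyl on an aromatic carbon. This is hydrogen in place of methyl on an aromatic carbon, para to a large group, so that 4-methylphenyl becomes phenyl.

Within the data shown here, no measured step removes this methyl or alters the (4-methylphenyl)carbamoyl group. Among the measured compounds shown here, the only single-place step, a 1.4-fold lower number from compound 1 to compound 2 (0.15 log units; within the scatter), puts 3-nitrophenyl in place of 4-methoxyphenyl and bears on the question only indirectly. Even that exchange of a whole substituted phenyl group stayed within the scatter, so no step beyond the scatter is expected in this assay, and the direction is uncertain. The expected step is small: a 1.2-fold lower number from compound 3 to compound 4 (0.07 log units; within the scatter). For compound 4 the estimated value is 230000 nM, with an expected range of 110000 nM to 450000 nM.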

Compound 4, half-maximal inhibitory concentration: 72300 nM
For compound 4 the middle estimate is 3.2-fold (0.50 log units) above the measured one, and the stated range ends above it.
By their numbers in this assay, from the lowest: compounds 2 and 1 (each within the scatter of the next); then compound 4; then compound 3.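

In this assay, taking away a single methyl from the aromatic carbon para to a large group, so that 4-methylphenyl becomes phenyl, gives a 3.7-fold lower number from compound 3 to compound 4 (0.57 log units; beyond the scatter). Among these compounds, this shows that this position is not silent in this read-out, even though the change is one heavy atom with no hydrogen-bond donor or acceptor, whereas the only earlier step, the exchange of one whole substituted phenyl group for another, gave a 1.4-fold lower number from compound 1 to compound 2 (0.15 log units; within the scatter) and stayed within the scatter. The new step is modest, and nothing available accounts for it, so it stands as an observation about this one pair.

With only hydrogen and methyl shown at this position, it remains open whether a chlorine, a methoxy group or a hydroxyl group on the same aromatic carbon would lower the number further, leave it where it is or raise it. From the compounds shown here alone, it also remains open whether the same exchange would give a step of similar size with the phenyl group attached directly to the aromatic nitrogen, rather than in the phenylcarbamoyl group.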